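Working notes on compound 2 and compound 3

A few compounds are considered here, and "the series" means these few. Any claim that something is new, unique, unknown or untested is made for them only; others in the source may bear on it.

Among the compounds with values here, compound 2 `COc1ccc(CN2CCc3nc(-c4ccccn4)nc(N4CCC(C(N)=O)CC4)c3C2)cc1` is the one member of the series with a number: in an assay on FRT cells with Cystic fibrosis transmembrane conductance regulator variant F508del (Homo sapiens) as the target, read by fluorescence, with a stated time of 25 min (on this read-out higher numbers stand for larger maximal responses and lower numbers for smaller maximal responses), compound 2 gives 86.6%. Within the data shown here, compound 1 `COc1ccc(CN2CCc3nc(-c4ccccn4)nc(N4CCN(CCN(C)C)CC4)c3C2)cc1` is recorded in this assay as "not active" (no number reported), so no step between measured compounds can be computed. Compound 3 `COc1ccc(CN2CCc3nc(-c4ccccn4)nc(NCCCn4ccnc4)c3C2)cc1` differs from compound 2 in one place: (3-(1H-imidazol-1-yl)propyl)amino in place of 4-carbamoylpiperidin-1-yl on an aromatic carbon. A six-membered non-aromatic ring leaves and a five-membered aromatic ring enters on the same aromatic carbon, with one more hydrogen-bond acceptor. Among the measured compounds shown here, with no measured step to lean on, the expected step in this assay is a number 26.6 percentage points lower from compound 2 to compound 3 (beyond the scatter), moderate and downward. Compound 3 is estimated at 60%, with a range of 20% to 95%.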

Compound 3, largest response reached (Emax), in percent of the reference or control that the assay uses in the Cystic fibrosis transmembrane conductance regulator assay: 40.6%
Estimate against measurement, compound 3: 19.4 percentage points above; the range from low to high includes it.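

In the Cystic fibrosis transmembrane conductance regulator assay, placing (3-(1H-imidazol-1-yl)propyl)amino where 4-carbamoylpiperidin-1-yl stood gives a number 46 percentage points lower from compound 2 to compound 3 (beyond the scatter) and shows that this aromatic carbon is sensitive to its substituent, although a numerical response remains. In a physicochemical assay for solubility, read by HPLC, with a stated time of 24 h, at pH 7.4, tested at 250 uM (on this read-out lower numbers stand for lower solubility and higher numbers for higher solubility), compound 2 gives 224000 nM and compound 3 gives 217000 nM within the scatter of each other. Nothing at hand bears on the reason for the step in response.

Going by these compounds, it remains open whether the step follows the imidazole ring, the propyl chain or the missing carboxamide. A piperidine carrying a carboxylic acid, or a longer chain ending in imidazole, would help separate these.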